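From compound 1 to compound 4: one group exchanged

This account rests on a few compounds, and the source may have more. Where it says the series, first, only, none or still open, it means among the compounds named here.

Measured so far in a functional assay, read by spectrophotometry, with a stated time of 3 min; on this read-out higher numbers stand for weaker inhibition and lower numbers for stronger inhibition:
- Compound 1 `Nc1ccccc1/N=C\c1cc(=O)oc2cc(OCc3ccccc3)cc(OCc3ccccc3)c12`: 7530 nM
- Compound 2 `Nc1ccccc1/N=C\c1cc(=O)oc2cc(OCc3ccccc3)ccc12`: 9250 nM
- Compound 3 `O=c1cc(-c2nc3ccccc3[nH]2)c2ccc(OCc3ccccc3)cc2o1`: "not active" (no number reported)

Only two of these compounds have numbers, and they cannot be told apart: the step is a 1.2-fold higher number from compound 1 to compound 2 (0.09 log units; within the scatter). Compound 1 therefore stands level with compound 2, while compound 3 has no number to compare.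

Compound 4 `O=c1cc(/C=N\Nc2ccc([N+](=O)[O-])cc2)c2c(OCc3ccccc3)cc(OCc3ccccc3)cc2o1` has not been measured. It is reached from compound 1 by one exchange: (4-nitrophenyl)amino in place of 2-aminophenyl on a double-bonded nitrogen. In words, (4-nitrophenyl)amino takes the place of 2-aminophenyl on a double-bonded nitrogen.

For the measured compounds named here, the one measured step, hydrogen in place of benzyloxy, concerns a different group, so it gives no size for this exchange. Compound 3, which also lacks the 2-aminophenyl group, is reported as "not active" (no number reported), so a result without a number remains possible. Going by the values given here, with no measured step pointing either way, no clear shift is expected in this assay.

The expected change is a 1.2-fold higher number from compound 1 to compound 4 (0.08 log units; within the scatter).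

For compound 4 the estimate is 9000 nM, with an expected range of 2500 nM to 32000 nM.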

Compound 4, half-maximal inhibitory concentration: 15500 nM
Compound 4: middle estimate off by 1.7-fold (0.24 log units), on the low side; the range from low to high includes it.
By their numbers in this assay, from the lowest: compounds 1, 2 and 4 (each within the scatter of the next, the first and the last beyond it).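

In this assay, exchanging 2-aminophenyl for (4-nitrophenyl)amino on the double-bonded nitrogen gives a 2.1-fold higher number from compound 1 to compound 4 (0.31 log units; beyond the scatter), the first step among these compounds to lie beyond the usual scatter, though only modestly. This shows that the group at this position can change the number, while compound 4 still gives a measurable value with a much altered group. No measurement available here explains the shift.

As far as these compounds go, the exchange alters several things at once, removing the ring's amino group, adding a nitro group and linking the ring through an extra nitrogen, so the part responsible remains open. A plain phenylamino group at this position would help separate these contributions, and a carboxylic acid in place of the nitro group would test whether other substituents on the ring give a different number.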